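Trimming One Methoxy from Compound 2

The source may report more compounds than this note shows. Statements on the series, on what has been measured and on what is new or still open speak of the compounds shown alone.

Compound 2 `COc1ccc(C(=O)/C=C/c2cc(-c3cc(OC)c(OC)c(OC)c3)n[nH]2)cc1OC` gives 3320 nM in a functional assay on NCI-H226 cells (Homo sapiens) for inhibition, read by sulforhodamine B assay, with a stated time of 48 h (a higher number here means a weaker inhibitor of growth, a lower number a stronger inhibitor of growth), and compound 1 `COc1cc(-c2cc(/C=C/C(=O)c3ccc(N)cc3)[nH]n2)cc(OC)c1OC` gives 3510 nM, so the two stand within the scatter of each other. Among the measured compounds shown here, the only step measured, a 1.1-fold lower number from compound 1 to compound 2 (0.02 log units; within the scatter), replaces the whole aryl group on the carbonyl carbon. Compound 3 `COc1ccc(C(=O)/C=C/c2cc(-c3cc(OC)c(OC)c(OC)c3)n[nH]2)cc1` differs from compound 2 by hydrogen in place of methoxy on an aromatic carbon, a smaller change on that same aryl group. Since the larger swap in a 1.1-fold lower number from compound 1 to compound 2 (0.02 log units; within the scatter) moved nothing beyond the scatter, no step beyond the scatter is expected here either. Compound 3 is therefore estimated at 3300 nM, between 1500 nM and 7500 nM, an expected step of a 1.0-fold lower number from compound 2 to compound 3 (0.00 log units; within the scatter).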

Compound 3, concentration for total growth inhibition: 4070 nM
Compound 3: the middle estimate sits 1.2-fold (0.09 log units) below what was measured, within the range that was stated.
By their numbers in this assay, from the lowest: compounds 2, 1 and 3 (each within the scatter of the next).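

In this assay, the change from 3,4-dimethoxyphenyl to 4-methoxyphenyl gives a 1.2-fold higher number from compound 2 to compound 3 (0.09 log units; within the scatter), so this methoxy group can go without a step beyond the scatter. On the same aryl group, methoxy in place of amino gives a 1.2-fold higher number from compound 1 to compound 3 (0.06 log units; within the scatter), so this exchange also stays within the scatter. No measurement offered here explains why these numbers stay together.

On these data alone, whether hydrogen in place of the remaining methoxy would move the number stays open. So does the effect of a carboxylic acid or a longer alkoxy chain on this aryl group.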